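A few compounds are considered here, and "the series" means these few. Any claim that something is new, unique, unknown or untested is made for them only; others in the source may bear on it.

Measured so far:
compound 1, `O=C(O)Cc1sc(C2COc3ccccc3O2)nc1-c1ccc(Cl)cc1`: 50%
compound 2, `O=C(O)Cc1sc(C(c2ccc(F)cc2)c2ccc(F)cc2)nc1-c1cccc(F)c1`: 80%

In an in vitro functional assay on HEK285-7 cells for antagonist activity at prostaglandin D2 receptor 2 (Homo sapiens), read by BRET and beta-arrestin recruitment (on this read-out higher numbers stand for larger maximal responses and lower numbers for smaller maximal responses), compound 2 gives 80%, the highest of the two numbers available. The nearest number belongs to compound 1, which in this assay gives 50%; the gap between the two lies beyond the usual scatter of this read-out, so compound 2 stands clearly above compound 1 on the largest response reached.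

Compound 3, `CN(C)c1cc(-c2nc(C(c3ccc(F)cc3)c3ccc(F)cc3)sc2CC(=O)O)ccn1`, is not yet measured. It differs from compound 2 in a single place: 2-(dimethylamino)pyridin-4-yl in place of 3-fluorophenyl on an aromatic carbon. The carboxymethyl group, the large group and the shared core are unchanged. Among the compounds with values here, no measured pair shows a change of this kind, so nothing measured tells how large the step will be; the only guidance is that compound 2 already sits high on the scale, which leaves more room below than above.

The step of a number 5 percentage points lower from compound 2 to compound 3 (within the scatter) is expected to be small, most likely none beyond the scatter, with a slight lean toward a lower number. Compound 3 is therefore estimated at 75%, with a range from 50% to 100%.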

Compound 3, largest response reached (reported as efficacy), in percent of the reference or control that the assay uses: 80%
Compound 3: middle estimate off by 5 percentage points, on the low side; measured number inside the range.
By their numbers in this assay, from the lowest: compound 1; then compounds 2 and 3 (each within the scatter of the next).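

Working notes on the aromatic carbon next to the ring nitrogen: in this assay the exchange of 3-fluorophenyl for 2-(dimethylamino)pyridin-4-yl gives no change at the digits printed from compound 2 to compound 3 (within the scatter) at this position. Within the data shown here, this is the first one-place comparison, and it shows that the read-out holds across a change from a carbon-only aromatic ring to one with a ring nitrogen, from 7 to 9 heavy atoms and from 0 to 2 hydrogen-bond acceptors. Nothing available bears on why the read-out holds across this exchange.

Among these compounds, the single step changes the ring and its substituent together, so an unsubstituted pyridin-4-yl or a 3-(dimethylamino)phenyl group would be needed to read each part separately. On these data alone, it also remains open whether this result extends to a larger amine on the pyridine ring, such as morpholine, or whether it holds when the large group on the shared core is different.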